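A few compounds are considered here, and "the series" means these few. Any claim that something is new, unique, unknown or untested is made for them only; others in the source may bear on it.

Compound 1, `Cc1ccc2[nH]c(CC(CC(=O)O)c3ccc(Cl)cc3)nc2c1`, gives 0% in an assay on isolated protein for inhibition of protein kinase C zeta type (Homo sapiens), read by 33P incorporation, tested at 50 uM; on this read-out higher numbers stand for a stronger effect at the one concentration tested and lower numbers for a weaker effect.
Compound 2, `CCc1ccc2[nH]c(CC(CC(=O)O)c3ccc(Cl)cc3)nc2c1`, gives 0% in this assay .

Both measured compounds show no inhibition at the single concentration tested. The one measured step, no change at the digits printed from compound 1 to compound 2 (within the scatter), is flat, so on the numbers shown compound 2 stands level with compound 1, and there is no sign that adding a carbon to the alkyl chain on the shared core does anything here.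

Compound 3, `COC(=O)c1ccc2[nH]c(CC(CC(=O)O)c3ccc(Cl)cc3)nc2c1`, carries a different kind of change: methoxycarbonyl in place of ethyl on an aromatic carbon. Among the compounds with values here, no measured step involves a methoxycarbonyl group, or an exchange of an alkyl group for a carbonyl-bearing one, so there is no direct guide from the data to the size or direction of its effect. The only available reference is the flat step already seen, which gives no reason to expect movement away from zero.

Because no change at the digits printed from compound 1 to compound 2 (within the scatter) showed no change, the step to compound 3 is expected to be a number 2 percentage points higher from compound 2 to compound 3 (within the scatter), that is, none beyond the scatter. Compound 3 is therefore estimated at 2%, with a range from -10% to 15%.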

Compound 3, a percentage reported as inhibition, at one concentration (the size of the read-out at that concentration, not a potency): 0%
Beside the measured number, compound 3's estimate is 2 percentage points above it, and the stated range covers the measured number.
By their numbers in this assay, from the lowest: compounds 1, 2 and 3 (each within the scatter of the next).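

In this assay, the exchange of ethyl for methoxycarbonyl on this aromatic carbon shows no change at the digits printed from compound 2 to compound 3 (within the scatter), and the exchange of methyl for methoxycarbonyl at the same place shows no change at the digits printed from compound 1 to compound 3 (within the scatter). The earlier step only lengthened a small alkyl group, whereas this change brings in a larger group with a double bond outside the aromatic rings and hydrogen-bond acceptors, and the reading at this one concentration still stays level. No separate measurement is available that could help interpret this flat result.

Within the data shown here, all three compounds give the same reading, so the series offers no active compound against which the effect of a change at this position could be judged, and it cannot show whether this position matters for the protein at all. An amine, a carboxylic acid or a longer chain on this aromatic carbon remains an open case, as does any replacement of the chlorine on the other aromatic ring.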